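This account rests on a few compounds, and the source may have more. Where it says the series, first, only, none or still open, it means among the compounds named here.

Measured so far in an ADME assay on MT4 cells (Homo sapiens) for cytotoxicity, read by MTT assay; a lower number here means that less compound is tolerated, a higher number that more compound is tolerated: compound 1 `Cc1cc(C#N)cc(C)c1Oc1ccnc(Nc2ccc(CN3CCCN(S(=O)(=O)C4CC4)CC3)cc2)n1`, "not active" (no number reported), with no number given; compound 2 `Cc1cc(C#N)cc(C)c1Oc1ccnc(Nc2ccc(CN3CCCN(S(C)(=O)=O)CC3)cc2)n1`, at 7850 nM; compound 3 `Cc1cc(C#N)cc(C)c1Oc1ccnc(Nc2ccc(CN3CCN(S(=O)(=O)C4CC4)CC3)cc2)n1`, at 4430 nM.

Compound 2 holds the highest of the two numbers. Its nearest neighbour is compound 3, and the step of a 1.8-fold lower number from compound 2 to compound 3 (0.25 log units; within the scatter) is a small one. Compound 1 stands apart, since for it this assay gave no number.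

Compound 4 `Cc1cc(/C=C/C#N)cc(C)c1Oc1ccnc(Nc2ccc(CN3CCCN(S(C)(=O)=O)CC3)cc2)n1` differs from compound 2 in one place: 2-cyanoethenyl in place of cyano on an aromatic carbon. Among the measured compounds shown here, none of the measured steps touches this position; the one measured step, from compound 2 to compound 3, alters the group on the saturated chain carbon instead, so it gives no direct guide. With nothing measured bearing on the change, the expectation rests on compound 2 alone, and the step of a 1.3-fold lower number from compound 2 to compound 4 (0.12 log units; within the scatter) is expected to stay within the scatter. Compound 4 is therefore estimated at 6000 nM, with a range from 2000 nM to 18000 nM.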

Compound 4, half-maximal cytotoxic concentration: 17400 nM
For compound 4 the middle estimate is 2.9-fold (0.46 log units) below the measured one, and the stated range covers the measured number.
By their numbers in this assay, from the lowest: compounds 3 and 2 (each within the scatter of the next); then compound 4.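

Placing 2-cyanoethenyl in place of cyano on this aromatic carbon gives the first measured change at this position, and in this assay it yields a 2.2-fold higher number from compound 2 to compound 4 (0.35 log units; beyond the scatter). The step is modest, but it shows that this carbon, which the earlier step on the saturated chain carbon left untouched, can shift the tolerated concentration on its own, with more compound tolerated after the longer group enters. Nothing available here accounts for this shift.

The compounds shown leave open whether a saturated 2-cyanoethyl group or a plain ethenyl group on this carbon would give a similar number in this assay, so the step cannot yet be assigned to the double bond, the nitrile or the added length. They also leave open whether 2-cyanoethenyl would act alike alongside the 4-(cyclopropylsulfonyl)piperazin-1-yl group of compound 3.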